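Aryl replaces carbamoylmethyl on the ring nitrogen: compound 4

This account rests on a few compounds, and the source may have more. Where it says the series, first, only, none or still open, it means among the compounds named here.

Compound 1 `CCOC(=O)C1=Cc2ccccc2OC1(OCc1cn(-c2ccc(C)cc2)nn1)C(F)(F)F`, compound 2 `CCOC(=O)C1=Cc2ccccc2OC1(OCc1cn(CC(=O)Nc2ccc(C)cc2)nn1)C(F)(F)F` and compound 3 `CCOC(=O)C1=Cc2ccccc2OC1(OCc1cn(CC(=O)Nc2ccc(I)cc2Cl)nn1)C(F)(F)F` share one core bearing the trifluoromethyl and the ethyl ester; they differ only in the group on the aromatic nitrogen of the five-membered aromatic ring with 3 nitrogen. In a functional assay on DU-145 cells (Homo sapiens) for inhibition, read by MTT assay, with a stated time of 24 h (on this read-out higher numbers stand for weaker inhibition and lower numbers for stronger inhibition), compound 3 gives 24400 nM. Compound 1 gives 30200 nM, and the gap a 1.2-fold lower number from compound 1 to compound 3 (0.09 log units; within the scatter) lies within the scatter. Compound 2 gives only a limit, > 150000 nM (the limit of > 150000 nM in this assay, at which 1 of the 3 values shown sits). The steps of an at least 4.9-fold higher number from compound 1 to compound 2 (0.69 log units; beyond the scatter) and an at least 6.1-fold lower number from compound 2 to compound 3 (0.78 log units; beyond the scatter) show that the carbamoylmethyl arms move the number beyond the scatter in either direction, whereas the swap between a carbamoylmethyl arm and a plain aryl on the ring nitrogen did not.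

Compound 4 `CCOC(=O)C1=Cc2ccccc2OC1(OCc1cn(-c2cccc(OC)c2)nn1)C(F)(F)F` carries 3-methoxyphenyl in place of ((2-chloro-4-iodophenyl)carbamoyl)methyl on an aromatic nitrogen. The step bearing on it is a 1.2-fold lower number from compound 1 to compound 3 (0.09 log units; within the scatter) read backwards, an aryl set directly on the aromatic nitrogen as in compound 1, and that step was within the scatter. No step beyond the scatter is therefore expected in this assay; for compound 4 the expected step is a 1.2-fold higher number from compound 3 to compound 4 (0.09 log units; within the scatter). Compound 4 is estimated at 30000 nM, with a range from 12000 nM to 80000 nM.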

Compound 4, half-maximal inhibitory concentration: > 150000 nM
Compound 4 was reported as a limit; the forecaster's own chance of this, stated with the estimate: 10%; middle value at least 5.0-fold (0.69 log units) from the limit.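

In this assay the change to 3-methoxyphenyl in place of 4-methylphenyl gives an at least 4.9-fold higher number from compound 1 to compound 4 (0.69 log units; beyond the scatter) and so shows that a directly attached aryl on the aromatic nitrogen does not by itself hold the number near that of compound 1. For the compounds shown here, the change away from the ((2-chloro-4-iodophenyl)carbamoyl)methyl arm gives an at least 6.1-fold higher number from compound 3 to compound 4 (0.78 log units; beyond the scatter) and so the within-scatter pair of the earlier compounds does not extend to every aryl, and neither arm type sorts the series: compound 1 and compound 3 go against any such rule. Compound 4 is reported only as a limit, as is compound 2, so the step between them cannot be read: the limit of > 150000 nM in this assay, at which 2 of the 4 values shown sit.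

The compounds shown do not separate the methoxy group from the place it holds on the phenyl ring, which 3-methylphenyl and 4-methoxyphenyl would address. On these data alone, what an amine or a carboxylic acid on that phenyl ring would give also stays open.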